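Small substituents on the chain carbon at the aromatic nitrogen

This account rests on a few compounds, and the source may have more. Where it says the series, first, only, none or still open, it means among the compounds named here.

Measured compounds:
- compound 1, `[N-]=[N+]=NCC(O)Cn1c(=O)n(C2OC(CO)[C@@H](O)[C@H]2O)c2nc(N)nc(O)c21`, 91%
- compound 2, `Nc1nc(O)c2c(n1)n(C1OC(CO)[C@@H](O)[C@H]1O)c(=O)n2CC(O)CO`, 136%
- compound 3, `N#Cc1cccc(Cn2c(=O)n(C3OC(CO)[C@@H](O)[C@H]3O)c3nc(N)nc(O)c32)c1`, 16%

In a functional assay on the whole organism (B cells) with Mus musculus as the target (a higher number here means a larger maximal response, a lower number a smaller maximal response), compound 3 stands lowest of the three numbers; the nearest is compound 1 and the furthest compound 2, both beyond the scatter. The two steps that bear on the change are a number 75 percentage points lower from compound 1 to compound 3 (beyond the scatter) and a number 120 percentage points lower from compound 2 to compound 3 (beyond the scatter): in each case the 3-cyanophenyl group on the saturated chain carbon bound to the aromatic nitrogen enters and the maximal response falls by a large amount.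

Compound 4, `Cn1c(=O)n(C2OC(CO)[C@@H](O)[C@H]2O)c2nc(N)nc(O)c21`, is not yet measured. The change from compound 3 is hydrogen in place of 3-cyanophenyl on a saturated chain carbon bound to an aromatic nitrogen. It removes the very group whose arrival coincided with the two large falls, so a large rise is expected in this assay, although the hydrogen that enters matches neither the 2-azido-1-hydroxyethyl of compound 1 nor the 1,2-dihydroxyethyl of compound 2, which leaves the size uncertain. The expected step is a number 64 percentage points higher from compound 3 to compound 4 (beyond the scatter). Compound 4 is estimated at 80%, within 30% to 140%.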

Compound 4, largest response reached (reported as maximal response), in percent of the reference or control that the assay uses: 99%
For compound 4 the middle estimate is 19 percentage points below the measured one, and the stated range covers the measured number.
By their numbers in this assay, from the lowest: compound 3; then compounds 1 and 4 (each within the scatter of the next); then compound 2.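

Methyl at this place gives a large response in this assay (a number 83 percentage points higher from compound 3 to compound 4 (beyond the scatter)), so among these compounds the low number goes with the 3-cyanobenzyl group alone, and no elaborate chain is needed to avoid it. Methyl also separates the two remaining chains: the 2-azido-1-hydroxyethyl group cannot be told apart from hydrogen here (a number 8 percentage points higher from compound 1 to compound 4 (within the scatter)), whereas the 1,2-dihydroxyethyl group can (a number 37 percentage points lower from compound 2 to compound 4 (beyond the scatter)), which leaves it as the only substituent shown with a gain over methyl. No measurement shown accounts for these steps.

Open, going by these compounds, is whether the low number follows the benzene ring or the nitrile, which a plain benzyl group would separate. Also open, on these data alone, is how an amine, a carboxylic acid or a longer alkyl chain at this place compares with methyl and with the 1,2-dihydroxyethyl group.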